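This account rests on a few compounds, and the source may have more. Where it says the series, first, only, none or still open, it means among the compounds named here.

Measured in a functional assay on M14 cells (Homo sapiens) for antiproliferative activity, with a stated time of 72 h; on this read-out higher numbers stand for weaker inhibition and lower numbers for stronger inhibition:

- compound 1 `C=CC[C@H]1C[C@]2([C@@H](C)Cc3ccc(OC)c(F)c3)OCOC2=CC1=O` gives 8 nM
- compound 2 `C=CC[C@H]1C[C@]2([C@@H](C)Cc3cc(C)c(OC)cc3F)OCOC2=CC1=O` gives 230 nM
- compound 3 `C=CC[C@H]1C[C@]2([C@@H](C)Cc3cc(F)c(OC)cc3F)OCOC2=CC1=O` gives 30 nM

Compound 3 sits in the middle of these numbers, as shown by a 3.8-fold higher number from compound 1 to compound 3 (0.57 log units; beyond the scatter) and a 7.7-fold lower number from compound 2 to compound 3 (0.88 log units; beyond the scatter). Compound 4 `C=CC[C@H]1C[C@]2([C@H](C)Cc3cc(F)c(OC)cc3F)OCOC2=CC1=O` changes only its spatial arrangement: the two compounds have the same atoms and bonds and differ only in configuration as drawn: 1 of 3 stereo elements differ; a stereocentre at a saturated chain carbon is drawn S in compound 3 and R in compound 4. Neither measured step tests such a change, since both alter a group on an aromatic carbon, so they offer only a rough sense of scale. All three measured compounds share the drawing of compound 3 at this carbon, and the data cannot show how the other arrangement behaves. A higher number is tentatively expected, with a step of similar or somewhat larger size: a 6.7-fold higher number from compound 3 to compound 4 (0.82 log units; beyond the scatter). For compound 4 the estimated value is 200 nM, with an expected range from 25 nM to 2000 nM.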

Compound 4, half-maximal inhibitory concentration: 10 nM
Compound 4: middle estimate off by 20-fold (1.30 log units), on the high side; measured number outside the range, below it.
By their numbers in this assay, from the lowest: compounds 1 and 4 (each within the scatter of the next); then compound 3; then compound 2.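

Until this point every step changed a group on an aromatic carbon, so the stereocentre at the saturated chain carbon had gone untested. Redrawing it from S to R gives a 3.0-fold lower number from compound 3 to compound 4 (0.48 log units; beyond the scatter) and shows that the arrangement at this carbon affects the read-out, with R the better of the two here. The step can be tied to this one carbon because nothing else changes: the fact that compounds 3 and 4 differ only in the configuration as drawn.

Going by these compounds, whether R brings a similar step with the ring substitution of compound 1 or compound 2 stays open. So does the effect of an amine on the aromatic ring.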